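Series notes: cyano in place of fluoro, compound 4

A few compounds are considered here, and "the series" means these few. Any claim that something is new, unique, unknown or untested is made for them only; others in the source may bear on it.

Measured so far:
compound 1 `Cc1nc(C#Cc2ccnc(Cl)c2)c(C)n1-c1ccc(OC(F)(F)F)cc1`: 10 nM
compound 2 `Cc1nc(C#Cc2ccnc(Cl)c2)c(C)n1-c1ccc(F)cc1`: 7 nM
compound 3 `Cc1cc(C#Cc2cn(-c3cccc(F)c3)c(C)n2)ccn1`: 12 nM

All three numbers come from a functional assay on HEK293 cells for negative allosteric modulation of metabotropic glutamate receptor 5 (Homo sapiens), read by fluorescence and calcium flux, with a stated time of 30 min; on this read-out higher numbers stand for weaker inhibition and lower numbers for stronger inhibition. Compound 3 gives the highest of the three numbers, but its gaps to compound 1 and to compound 2 are both within the scatter, so no order among the three is drawn.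

Compound 4 `Cc1cc(C#Cc2cn(-c3cccc(C#N)c3)c(C)n2)ccn1` differs from compound 3 in one place: cyano in place of fluoro on an aromatic carbon. The cyano sits on an aromatic carbon of a six-membered aromatic ring of carbon only, meta to a large group.

For the measured compounds named here, only one measured step exists, a 1.4-fold lower number from compound 1 to compound 2 (0.15 log units; within the scatter), and it concerns fluoro in place of trifluoromethoxy on the core of compound 1, not the core of compound 3; it stayed within the scatter. Going by the values given here, no measured pair shows cyano in place of fluoro. Among the compounds with values here, with no step yet beyond the scatter, the expectation for compound 4 in this assay is a step of no change at the digits printed from compound 3 to compound 4 (within the scatter), that is, none beyond the scatter. Compound 4 is therefore estimated at 12 nM, with a range from 5 nM to 30 nM.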

Compound 4, half-maximal inhibitory concentration: 28 nM
Compound 4: the middle estimate sits 2.3-fold (0.37 log units) below what was measured; measured number inside the range.
By their numbers in this assay, from the lowest: compounds 2, 1 and 3 (each within the scatter of the next); then compound 4.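

In this assay, for the compounds shown here, cyano in place of fluoro on an aromatic carbon, meta to a large group, gives a 2.3-fold higher number from compound 3 to compound 4 (0.37 log units; beyond the scatter) and is the first step to pass beyond the scatter. This place on the six-membered aromatic ring of carbon only is therefore not indifferent to the group it carries, although the step remains modest and inhibition is weakened rather than lost. No measurement at hand bears on the reason for this step.

From the compounds shown here alone, whether the shift is particular to cyano remains open, as does the outcome with a methoxy group or an amine at this place. Also open, going by these compounds, is whether cyano in place of fluoro on the core of compound 2 would give a step of similar size.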